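The compounds below may be only part of what the source reports. "The series", "measured", "known", "first", "only" and "open" are said of these compounds alone.

Working notes on the series. Three analogues sharing one core have been measured in a functional assay on MCF7 cells (Homo sapiens) for inhibition, read by MTT assay, with a stated time of 48 h; a lower number here means a stronger inhibitor, a higher number a weaker inhibitor. Compound 1 `CCOC(=O)C1=C(NN=C(C(C)=O)C(C)=O)Nc2[nH]nc(C)c2C1c1ccc(N(C)C)cc1` gives 9740 nM. Compound 2 `CCOC(=O)C1=C(N/C=N/c2nnc(S(N)(=O)=O)s2)Nc2[nH]nc(C)c2C1c1ccc(N(C)C)cc1` gives 34500 nM, and compound 3 `CCOC(=O)C1=C(N/N=C(/Br)c2ccccc2)Nc2[nH]nc(C)c2C1c1ccc(N(C)C)cc1` gives 78400 nM. Compound 2 thus stands second highest of the three numbers: its nearest neighbour is compound 3, with a 2.3-fold higher number from compound 2 to compound 3 (0.36 log units; beyond the scatter), and its furthest is compound 1, with a 3.5-fold higher number from compound 1 to compound 2 (0.55 log units; beyond the scatter). The unmeasured compound 4 `CCOC(=O)C1=C(N/N=C(/C(=O)Br)c2ccc(Cl)cc2)Nc2[nH]nc(C)c2C1c1ccc(N(C)C)cc1` differs from compound 2 on an amine nitrogen whose other neighbours are a double-bonded ring carbon: a group of 12 heavy atoms (8 carbon, 1 nitrogen, 1 oxygen, 1 chlorine, 1 bromine; one six-membered aromatic ring of carbon only) in place of a group of 11 heavy atoms (3 carbon, 4 nitrogen, 2 oxygen, 2 sulfur; one five-membered aromatic ring with 3 hetero atoms), on an amine nitrogen. Within the data shown here, the measured step bearing most directly on this is the one in which a group carrying one six-membered aromatic ring of carbon only likewise replaced the five-membered aromatic ring with 3 hetero atoms, namely a 2.3-fold higher number from compound 2 to compound 3 (0.36 log units; beyond the scatter); the step of an 8.0-fold higher number from compound 1 to compound 3 (0.91 log units; beyond the scatter) points the same way. Compound 4 is therefore expected to land near compound 3. The expected step is a 1.7-fold higher number from compound 2 to compound 4 (0.24 log units; within the scatter). For compound 4 in this assay the estimate is 60000 nM, with a range from 20000 nM to 150000 nM.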

Compound 4, half-maximal inhibitory concentration: 46300 nM
Compound 4: the middle estimate sits 1.3-fold (0.11 log units) above what was measured; the measured number falls inside the stated range.
By their numbers in this assay, from the lowest: compound 1; then compounds 2, 4 and 3 (each within the scatter of the next, the first and the last beyond it).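

On the amine nitrogen, in this assay, the group of 12 heavy atoms leaves compound 4 within the scatter of two compounds that lie beyond the scatter of each other: a 1.3-fold higher number from compound 2 to compound 4 (0.13 log units; within the scatter), and a 1.7-fold lower number from compound 3 to compound 4 (0.23 log units; within the scatter). The group without a ring stays apart, with a 4.8-fold higher number from compound 1 to compound 4 (0.68 log units; beyond the scatter), so all three ring-bearing groups shown now give higher numbers than compound 1, and no compound shown goes against this. No measurement at hand explains these steps.

Compared with compound 3, compound 4 carries both the chlorine and the extra carbonyl, and neither can be read alone. Going by these compounds, it remains open whether a ring-free group ending in an amine or a carboxylic acid on this nitrogen would stand with compound 1 or with the ring-bearing compounds.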